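The source may report more compounds than this note shows. Statements on the series, on what has been measured and on what is new or still open speak of the compounds shown alone.

For the measured compounds named here, in an ADME assay on microsomes from liver (Rattus norvegicus) for metabolic stability, read by LC-MS, using NADPH, with stated times of 5 min and 30 min, tested at 1 uM (on this read-out higher numbers stand for fast clearance and lower numbers for slow clearance), compound 2 `COC(=O)c1ccc(-c2cnc3ncn(C(C)c4c(F)cc5ncccc5c4F)c3n2)cc1F` gives 179 uL/min, the highest of the two numbers measured so far; compound 1 `CC(c1c(F)cc2ncccc2c1F)n1cnc2ncc(-c3ccncc3)nc21` gives 77 uL/min. Going by the values given here, the only measured step, a 2.3-fold higher number from compound 1 to compound 2 (0.37 log units; beyond the scatter), put 3-fluoro-4-(methoxycarbonyl)phenyl in place of pyridin-4-yl on an aromatic carbon. Compound 3 `CC(c1c(F)cc2ncccc2c1F)n1cnc2ncc(-c3cnc4ccccc4c3)nc21` differs from compound 2 by quinolin-3-yl in place of 3-fluoro-4-(methoxycarbonyl)phenyl on an aromatic carbon. That single step gives only a rough guide, since quinolin-3-yl is neither of the groups compared there, so a number between the two measured values seems the safest expectation. Compound 3 is therefore estimated to give 120 uL/min, within 60 uL/min to 240 uL/min, an expected step of a 1.5-fold lower number from compound 2 to compound 3 (0.17 log units; within the scatter).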

Compound 3, intrinsic clearance in a liver preparation (reported as CLH), per the amount of preparation that the assay uses: 275 uL/min
The estimate for compound 3 lay 2.3-fold (0.36 log units) below the measured number; measured number outside the range, above it.
By their numbers in this assay, from the lowest: compound 1; then compounds 2 and 3 (each within the scatter of the next).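

In this assay, quinolin-3-yl at this position gives a 3.6-fold higher number from compound 1 to compound 3 (0.55 log units; beyond the scatter), so pyridin-4-yl now stands apart from two different groups, not just one. Set against 3-fluoro-4-(methoxycarbonyl)phenyl, the same group gives a 1.5-fold higher number from compound 2 to compound 3 (0.19 log units; within the scatter), so this read-out does not separate these two groups. Nothing measured here explains the difference from pyridin-4-yl. Still open, as far as these compounds go, is whether a plain phenyl or a morpholine on this aromatic carbon would give a number like that of compound 1 or like that of compound 3.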